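Compound 1 to compound 4: ethoxy in place of methyl

The source may report more compounds than this note shows. Statements on the series, on what has been measured and on what is new or still open speak of the compounds shown alone.

In a functional assay on HCC 2998 cells (Homo sapiens) for antiproliferative activity (a higher number here means a weaker inhibitor of growth, a lower number a stronger inhibitor of growth), compound 1 `COc1ccc(-c2nc3cc(F)ccc3s2)cc1C` gives 540 nM and holds the middle place among the three measured compounds, with both gaps beyond the scatter. Compound 3 `COc1ccc(-c2nc3cc(F)ccc3s2)c(OC)c1OC` gives a lower number at 37 nM while compound 2 `COc1cc(-c2nc3cc(F)ccc3s2)cc(OC)c1OC` gives a higher one at 21100 nM on the same read-out. For the measured compounds named here, compound 4 `CCOc1cc(-c2nc3cc(F)ccc3s2)ccc1OC` has no measurement yet. Its difference from compound 1 is ethoxy in place of methyl on an aromatic carbon and amounts to ethoxy in place of methyl on an aromatic carbon, ortho to a methoxy group and meta to a large group.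

Going by the values given here, no two measured compounds differ in one place only, so no measured step bears directly on this change. The direction therefore stays uncertain, and the distance from compound 3 at 37 nM to compound 2 at 21100 nM argues for a wide range. A modest move to a lower number in this assay is expected, only a little beyond the scatter. The expected step is a 2.7-fold lower number from compound 1 to compound 4 (0.43 log units; beyond the scatter) and carries low confidence. For compound 4 the estimated value is 200 nM with an expected range of 20 nM to 2500 nM at this stage.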

Compound 4, concentration for 50% growth inhibition: 3320 nM
Compound 4: the middle estimate sits 17-fold (1.22 log units) below what was measured, and the stated range ends below it.
By their numbers in this assay, from the lowest: compound 3; then compound 1; then compound 4; then compound 2.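

In this assay, ethoxy in place of methyl on this aromatic carbon, ortho to a methoxy group and meta to a large group, gives a 6.1-fold higher number from compound 1 to compound 4 (0.79 log units; beyond the scatter). For the compounds shown here, this is the first single-place step, and it shows that the group on this carbon matters to growth inhibition: of the two groups compared here, methyl gives the stronger inhibitor. Nothing at hand explains the loss.

Ethoxy differs from methyl both in its oxygen, a hydrogen-bond acceptor, and in its longer chain, so this one step cannot separate the two changes. A hydroxyl, a chlorine or a propoxy chain on the same carbon would show how far the trend extends and which of the two differences carries it.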